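Back from an arylamino group to a small cyclic amine

This account rests on a few compounds, and the source may have more. Where it says the series, first, only, none or still open, it means among the compounds named here.

Three measured compounds share one core and differ only in the group on a double-bonded ring carbon. Compound 1 `O=C1C=C(N2CCC2)C(=O)c2c1nc1n2[C@H]2OC[C@@H](O)[C@H]2OC1` carries an azetidin-1-yl group there. In a functional assay on HeLa cells (Homo sapiens) for inhibition, read by sulforhodamine B assay (on this read-out lower numbers stand for stronger inhibition and higher numbers for weaker inhibition), compound 1 gives only a limit, > 16000 nM, and not a number. Compound 2 `O=C1C=C(Nc2cccc(F)c2)C(=O)c2c1nc1n2[C@H]2OC[C@@H](O)[C@H]2OC1` carries a (3-fluorophenyl)amino group, and in this assay compound 2 gives 6440 nM. Compound 3 `O=C1C=C(Nc2ccc(Br)cc2)C(=O)c2c1nc1n2[C@H]2OC[C@@H](O)[C@H]2OC1` carries a (4-bromophenyl)amino group, and in this assay compound 3 gives 3830 nM, the lowest of the two numbers; the step of a 1.7-fold lower number from compound 2 to compound 3 (0.23 log units; within the scatter) stays within the scatter. The steps of an at least 2.4-fold lower number from compound 1 to compound 2 (0.39 log units; beyond the scatter) and an at least 4.1-fold lower number from compound 1 to compound 3 (0.62 log units; beyond the scatter) show that an arylamino group in place of the small cyclic amine lowers the number beyond the scatter. Compound 1 itself sits at the limit of > 16000 nM in this assay, at which 1 of the 3 values shown sits.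

Compound 4 `O=C1C=C(N2CCCC2)C(=O)c2c1nc1n2[C@H]2OC[C@@H](O)[C@H]2OC1` takes the change (pyrrolidin-1-yl in place of (4-bromophenyl)amino on a double-bonded ring carbon). Pyrrolidin-1-yl is, like azetidin-1-yl, a small saturated cyclic amine, so the step of an at least 4.1-fold lower number from compound 1 to compound 3 (0.62 log units; beyond the scatter) read in reverse is the guide: the number is expected to rise, a 3.9-fold higher number from compound 3 to compound 4 (0.59 log units; beyond the scatter), back toward the limit shown by compound 1. Compound 4 is therefore estimated at 15000 nM in this assay, within 4000 nM to 40000 nM, with a real chance that only a limit is reported.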

Compound 4, half-maximal inhibitory concentration: > 16000 nM
Compound 4: no number, only a limit (the forecaster's own chance of this, stated with the estimate: 55%); middle value at least 1.0-fold (0.02 log units) away from the limit.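

Pyrrolidin-1-yl gives the same picture as azetidin-1-yl: in this assay, replacing the arylamino group gives an at least 4.1-fold higher number from compound 3 to compound 4 (0.62 log units; beyond the scatter), and likewise an at least 2.4-fold higher number from compound 2 to compound 4 (0.39 log units; beyond the scatter). Among these four compounds, both arylamino compounds (compound 2 and compound 3) therefore give numbers, whereas both small cyclic amines do not, and no compound goes against this split. Compound 4 gives only a limit and not a number, the same limit as compound 1: the limit of > 16000 nM in this assay, at which 2 of the 4 values shown sit.

From the compounds shown here alone, the step from compound 1 to compound 4 cannot be read, so any effect of ring size between these two amines remains unknown. The change also removes an aromatic ring and a hydrogen-bond donor together, leaving open which one matters; cyclohexylamino, which keeps the donor without the aromatic ring, and methyl(phenyl)amino, which keeps the aromatic ring without the donor, would separate the two.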